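The source may hold more compounds than are shown below. What is called first, only, known or untested is meant among the compounds shown, and "the series" means these compounds.

Going by the values given here, compound 2, `NCCCNc1c(C(=O)NCc2ccc(F)cc2)nc(Br)c2cccnc12`, is the one compound in this set that gives an actual number: in a functional assay on HCT-116 cells (Homo sapiens) for cytotoxicity, read by MTT assay, with a stated time of 72 h (on this read-out lower numbers stand for stronger inhibition and higher numbers for weaker inhibition), compound 2 gives 18000 nM. Compound 1, `CNCCCNc1c(C(=O)NCc2ccc(F)cc2)nc(Br)c2cccnc12`, returns in this assay a value of > 10000 nM, which is a limit of the assay rather than a number. Among the compounds with values here, the step that the limit leaves unreadable from compound 1 to compound 2 is therefore of unreadable size, and the only evidence on measured steps is the limit of > 10000 nM in this assay, at which 1 of the 2 values shown sits, which reads as a limit in the same way. Compound 3 is `CN(C)CCCNc1c(C(=O)NCc2ccc(F)cc2)nc(Br)c2cccnc12`. It differs from compound 2 by dimethylamino in place of amino on a saturated chain carbon, three bonds along the chain from a nitrogen on an aromatic ring. Within the data shown here, the one measured change that touches this chain nitrogen, the step from compound 1 to compound 2, cannot be sized, so nothing measured argues for a shift in either direction. Compound 3 is therefore expected to give a value close to that of compound 2, with a wide range. The step of a 1.2-fold lower number from compound 2 to compound 3 (0.08 log units; within the scatter) is thus estimated to stay within the usual scatter. Compound 3 is estimated at 15000 nM, between 5000 nM and 60000 nM.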

Compound 3, half-maximal inhibitory concentration: > 10000 nM
Compound 3 ended at the assay's limit (the forecaster's own chance of this, stated with the estimate: 50%); the middle value does not contradict the limit.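

In this assay compound 3 gives > 10000 nM, which is a limit of the assay and not a number. None of the steps joining compound 1, compound 2 and compound 3 can be read: the limit of > 10000 nM in this assay, at which 2 of the 3 values shown sit.

The compounds shown leave open how far, and in which direction, methyl in place of hydrogen or dimethylamino in place of amino moves the value.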